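Replacing cyclopentyl with a fluoropyridinyl on the alkyne

The source may report more compounds than this note shows. Statements on the series, on what has been measured and on what is new or still open speak of the compounds shown alone.

Compound 3 `C[C@@H](NC(=O)c1ccc(C#CC2CCCC2)cn1)C(C)(C)O` gives 14.8% in an ADME assay on HEK293 cells for agonist activity at metabotropic glutamate receptor 5 (Rattus norvegicus), read by fluorescence and calcium flux (a lower number here means a smaller maximal response, a higher number a larger maximal response), the lowest of the three numbers recorded. Compound 1 `C[C@@H](NC(=O)c1ccc(C#Cc2ccc(F)cc2F)cn1)C(C)(C)O` gives 38.2%, and compound 2 `Cc1ccccc1C#Cc1ccc(C(=O)N[C@H](C)C(C)(C)O)nc1` gives 24.1%. The step of a number 9.3 percentage points lower from compound 2 to compound 3 (within the scatter) lies within the scatter, whereas a number 23.4 percentage points lower from compound 1 to compound 3 (beyond the scatter) is beyond it. Compound 4 `C[C@@H](NC(=O)c1ccc(C#Cc2cc(F)ccn2)cn1)C(C)(C)O` differs from compound 3 in one place: 4-fluoropyridin-2-yl in place of cyclopentyl on a triple-bonded carbon. Both measured steps that bear on this change run from an aromatic ring to cyclopentyl and go downward, one modestly and one within the scatter. Going the other way, a modest rise is expected, estimated as a number 15.2 percentage points higher from compound 3 to compound 4 (beyond the scatter). Compound 4 is therefore expected to give about 30%, within a range from 14% to 48%.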

Compound 4, largest response reached (reported as efficacy), in percent of the reference or control that the assay uses: 33%
Beside the measured number, compound 4's estimate is 3 percentage points below it, and the stated range covers the measured number.
By their numbers in this assay, from the lowest: compounds 3, 2, 4 and 1 (each within the scatter of the next, the first and the last beyond it).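

Changing to the aromatic ring gives a number 18.2 percentage points higher from compound 3 to compound 4 (beyond the scatter) in this assay, so on this triple-bonded carbon a ring holding a nitrogen also stands clear of cyclopentyl, not only the all-carbon aromatic rings. The new ring is not separated from either of those rings, with a number 8.9 percentage points higher from compound 2 to compound 4 (within the scatter) and a number 5.2 percentage points lower from compound 1 to compound 4 (within the scatter) both as printed. As far as these compounds go, whether the nitrogen or the fluorine of 4-fluoropyridin-2-yl counts for more stays open, as does the response with an unsubstituted pyridinyl or with an amine on the ring. Nothing measured here accounts for the rise.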